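The source may report more compounds than this note shows. Statements on the series, on what has been measured and on what is new or still open speak of the compounds shown alone.

Measured compounds in a functional assay on MCF7 cells (Homo sapiens) for antiproliferative activity, read by MTT assay, with a stated time of 72 h; on this read-out higher numbers stand for weaker inhibition and lower numbers for stronger inhibition:
Compound 2, `O=C1O[C@H]([C@@H](O)Cn2cc(-c3cccc(O)c3)nn2)C(OCc2ccccc2)=C1OCc1ccccc1`: compound 2 gives 51800 nM.
Compound 1, `O=C1O/C(=C\Cn2cc(-c3cc(F)cc(F)c3)nn2)C(OCc2ccccc2)=C1OCc1ccccc1`: compound 1 reaches only the assay limit, > 100000 nM.
Compound 3, `CCCCCc1ccc(-c2cn(C/C=C3\OC(=O)C(OCc4ccccc4)=C3OCc3ccccc3)nn2)cc1`: compound 3 likewise reaches only the assay limit, > 100000 nM.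

Within the data shown here, compound 2 holds the only number in this assay; the other two values are limits, as summarised in the limit of > 100000 nM in this assay, at which 2 of the 3 values shown sit. Among the measured compounds shown here, the sole step between measured compounds that differ in one place, a step that the two limits leave unreadable from compound 1 to compound 3, therefore cannot be read in size or direction.

Compound 4, `CCCCCCCCCCc1cn(C[C@H](O)[C@H]2OC(=O)C(OCc3ccccc3)=C2OCc2ccccc2)nn1`, differs from compound 2 by decyl in place of 3-hydroxyphenyl on an aromatic carbon. For the measured compounds named here, no measured step covers an exchange of this kind: the step from compound 1 to compound 3 concerns a different group on the core of compound 1 and is unreadable in any case. Going by the values given here, compound 4 keeps the core of compound 2, the one compound that gave a number, so the expectation rests on that value alone.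

In this assay compound 4 is expected at 50000 nM, with a range from 10000 nM to 200000 nM. The expected step of a 1.0-fold lower number from compound 2 to compound 4 (0.02 log units; within the scatter) is none beyond the scatter, and a limit report instead of a number remains a real possibility in view of the limit of > 100000 nM in this assay, at which 2 of the 3 values shown sit.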

Compound 4, half-maximal inhibitory concentration: 80 nM
Estimate against measurement, compound 4: 630-fold (2.80 log units) above; the measured number lies below the stated range.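

In this assay, the aromatic carbon of the five-membered aromatic ring with 3 nitrogen proves highly sensitive to its substituent: decyl in place of 3-hydroxyphenyl gives a 650-fold lower number from compound 2 to compound 4 (2.81 log units; beyond the scatter) on the core shared by the two compounds. Among these compounds, the earlier compounds could not show this, as their only step, from compound 1 to compound 3, cannot be read and concerns a different exchange on a different core; here, a group with no ring and no hydrogen-bond donor at this position is compatible with a much lower number than 3-hydroxyphenyl. Compound 4 also adds a second true number to a set otherwise bounded by limits: the limit of > 100000 nM in this assay, at which 2 of the 4 values shown sit.

This single exchange removes the ring and the hydroxyl together while bringing in the chain, so the compounds shown do not separate the contribution of each. From the compounds shown here alone, it remains open whether a shorter chain such as hexyl, a longer chain such as dodecyl, or a decyl chain ending in an amine or a carboxylic acid would keep the low number, and whether decyl would do the same on the core of compound 1.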